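Swapping the Aryl Group in a Sulfonamide Series

The source may report more compounds than this note shows. Statements on the series, on what has been measured and on what is new or still open speak of the compounds shown alone.

Measured so far:
compound 1 `COc1ccc(S(=O)(=O)N2CCc3cccc(-c4ccc([N+](=O)[O-])cc4)c32)cc1`: 51.3 nM
compound 2 `COc1ccc(S(=O)(=O)N2CCc3cccc(-c4cccs4)c32)cc1`: 251 nM

In a functional assay on KB-VIN10 cells (Homo sapiens) for inhibition, with a stated time of 72 h (a lower number here means a stronger inhibitor, a higher number a weaker inhibitor), compound 1 gives 51.3 nM and compound 2 gives 251 nM. For the measured compounds named here, compound 2 therefore stands with the highest number of the two, the only comparison being compound 1 with a number that is lower by a 4.9-fold higher number from compound 1 to compound 2 (0.69 log units; beyond the scatter).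

The unmeasured compound 3 `COc1ccc(S(=O)(=O)N2CCc3cccc(-c4ccc(N)cc4)c32)cc1` differs from compound 2 by 4-aminophenyl in place of thiophen-2-yl on an aromatic carbon. Going by the values given here, the one step with a bearing on this is the move from compound 1 to compound 2, in which a thiophen-2-yl replaced a six-membered carbon ring and the number rose by a 4.9-fold higher number from compound 1 to compound 2 (0.69 log units; beyond the scatter). Restoring a six-membered carbon ring, now as 4-aminophenyl, is expected to pull the number back toward compound 1, though how far a 4-aminophenyl tracks a 4-nitrophenyl is not known from these two compounds. Compound 3 is thus estimated to show a step of a 2.8-fold lower number from compound 2 to compound 3 (0.45 log units; beyond the scatter), giving an expected value of 90 nM with a range of 25 nM to 320 nM.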

Compound 3, half-maximal inhibitory concentration: 262 nM
Compound 3: the middle estimate sits 2.9-fold (0.46 log units) below what was measured, and the stated range covers the measured number.
By their numbers in this assay, from the lowest: compound 1; then compounds 2 and 3 (each within the scatter of the next).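

In this assay, a six-membered carbon ring alone does not bring the number down at this aromatic carbon: 4-aminophenyl in place of thiophen-2-yl gives a 1.0-fold higher number from compound 2 to compound 3 (0.02 log units; within the scatter), so these two groups cannot be told apart here. What separates the compounds is the group carried on the phenyl ring, as amino in place of nitro gives a 5.1-fold higher number from compound 1 to compound 3 (0.71 log units; beyond the scatter), a step much like the one already seen on leaving 4-nitrophenyl for thiophen-2-yl. Nothing available explains this difference between nitro and amino.

The compounds shown leave open what an unsubstituted phenyl would give at this position, and so whether nitro lowers the number or amino raises it. They also leave open whether a nitrile or a carboxylic acid on the phenyl ring would track nitro or amino.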